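The compounds below may be only part of what the source reports. "The series", "measured", "known", "first", "only" and "open" are said of these compounds alone.

Working notes on the series: in a functional assay on FaDu cells (Homo sapiens) for cytotoxicity, read by MTT assay, with a stated time of 72 h (on this read-out lower numbers stand for higher toxicity in this test and higher numbers for lower toxicity in this test), compound 1 (`COc1ncc(NC(=O)C(=O)c2cn(C(C)C)c3ccccc23)cn1`) gives 171 nM, and compound 2 (`COc1ccc(NC(=O)C(=O)c2cn(C(C)C)c3ncccc23)cn1`) gives 126 nM. Within the data shown here, these two values lie within the usual scatter of each other, so compound 2 stands level with compound 1 on the numbers so far. Compound 3 (`COCCn1cc(C(=O)C(=O)Nc2ccc(OC)nc2)c2cccnc21`) follows from compound 2 with 2-methoxyethyl in place of isopropyl on an aromatic nitrogen. Among the measured compounds shown here, no measured pair shows a change at this nitrogen, so the expectation rests on the structural change alone. A small step toward higher numbers is expected in this assay, and it may not exceed the scatter. The estimated move is a 1.5-fold higher number from compound 2 to compound 3 (0.18 log units; within the scatter). For compound 3 the expected value is 190 nM, with an estimated range of 70 nM to 520 nM.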

Compound 3, concentration lethal to 50% of the cells: 27 nM
For compound 3 the middle estimate is 7.0-fold (0.85 log units) above the measured one; measured number below the stated range.
By their numbers in this assay, from the lowest: compound 3; then compounds 2 and 1 (each within the scatter of the next).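

In this assay, among these compounds, the substituent on this aromatic nitrogen of the five-membered ring clearly matters: 2-methoxyethyl in place of isopropyl gives a 4.7-fold lower number from compound 2 to compound 3 (0.67 log units; beyond the scatter), the only step read so far and one beyond the scatter. Lower numbers here mean higher toxicity in this test, so the swap to a chain carrying an oxygen moves the series in that direction, with no ring or net charge entering. Nothing at hand bears on why the step is this large.

The compounds shown leave open whether the oxygen or the chain itself carries the change, a question that a plain butyl chain or a longer ether chain would address. Also open, as far as these compounds go, is whether a terminal amine on this nitrogen would be tolerated, and whether the same swap holds on the core of compound 1.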